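Pyridin-3-yl in Place of Indol-3-yl on a Shared Core

The source may hold more compounds than are shown below. What is called first, only, known or untested is meant among the compounds shown, and "the series" means these compounds.

Compound 1 `CCCCCCCCCCCCCCCCCCNC(=O)[C@H]1CSC(Cc2ccccc2)N1`: in a functional assay on RH7777 cells (Homo sapiens) for antiproliferative activity against RH7777 (Rattus norvegicus), read by sulforhodamine B assay (on this read-out higher numbers stand for weaker inhibition and lower numbers for stronger inhibition), compound 1 gives > 20000 nM, a limit of the assay.
Compound 2 `CCCCCCCCCCCCCCCCCCNC(=O)[C@H]1CSC(c2c[nH]c3ccccc23)N1`: in this assay compound 2 gives > 20000 nM, also a limit.

Compound 2 therefore stands only at a limit, with no number behind it, and the step that the two limits leave unreadable from compound 1 to compound 2 cannot be read. Compound 3 `CCCCCCCCCCCCCCCCCCNC(=O)[C@H]1CSC(c2cccnc2)N1` differs by pyridin-3-yl in place of 1H-indol-3-yl on a saturated ring carbon. Among the measured compounds shown here, the single measured step concerns the same saturated ring carbon but offers no size, because of the limit of > 20000 nM in this assay, at which 2 of the 2 values shown sit. No direction can be expected from it; compound 3 is expected to stay at a limit too, with an estimated value of 30000 nM (range 15000 nM to 80000 nM). The expected step is a step that the limit leaves unreadable from compound 2 to compound 3.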

Compound 3, half-maximal inhibitory concentration: 10500 nM
Compound 3: middle estimate off by 2.9-fold (0.46 log units), on the high side, and the stated range ends above it.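

Compound 3 is the only one of the three with a real number rather than a limit in this assay, so this saturated ring carbon now has a measured value tied to it. Pyridin-3-yl in place of 1H-indol-3-yl gives an at least 1.9-fold lower number from compound 2 to compound 3 (0.27 log units; that floor lies within the scatter), and in place of benzyl it gives an at least 1.9-fold lower number from compound 1 to compound 3 (0.27 log units; that floor lies within the scatter). Neither step has a known full size, because both starting values are limits and not numbers: the limit of > 20000 nM in this assay, at which 2 of the 3 values shown sit.

Still open, as far as these compounds go, is how a plain phenyl ring would read at this carbon, and whether a group carrying an amine or a carboxylic acid there would give a lower number.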